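This account rests on a few compounds, and the source may have more. Where it says the series, first, only, none or still open, it means among the compounds named here.

Compound 3 `Cc1cn2c(-c3cn[nH]c3)cnc2c(Nc2cc(C(c3ccccn3)N3CCCC3)ns2)n1` shares its core with compound 1 `Cc1cn2c(-c3cn[nH]c3)cnc2c(Nc2cc(Cc3ccccn3)ns2)n1` and compound 2 `Cc1cn2c(-c3cn[nH]c3)cnc2c(Nc2cc(Cc3ccncc3)ns2)n1`; the three differ only in one side group. In an ADME assay on the whole organism for pharmacokinetics, with Rattus norvegicus as the target, with a stated time of 6 h, at a dose of 10 mg/kg by the oral route (a higher number here means more compound in the circulation at the dose given, a lower number less compound in the circulation), compound 1 gives 6880 ng.h/mL. For compound 2 the outcome in this assay is "not determined" (no result reported), so no number is available for it. For the measured compounds named here, compound 3 gives 9.15 ng.h/mL in this assay, the lowest of the two numbers known, with compound 1 as its only measured neighbour. Going by the values given here, the one measured step that touches this side group is a 750-fold lower number from compound 1 to compound 3 (2.88 log units; beyond the scatter).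

Compound 4 `Cc1cn2c(-c3cn[nH]c3)cnc2c(Nc2cc(C(c3ccccn3)N3CCCCC3)ns2)n1` differs from compound 3 in a single place: piperidin-1-yl in place of pyrrolidin-1-yl on a saturated chain carbon bound to two aromatic carbons. Among the compounds with values here, no measured pair shows an exchange of one such saturated ring for another. The step from compound 1 to compound 3 shows what attaching such a ring did, but it gives no guide to swapping one ring for a slightly larger one, and both compounds 3 and 4 carry the ring. With nothing to point either way, the expectation for this assay is a step within the usual scatter, with no direction favoured.

On that basis compound 4 is expected to give about 10 ng.h/mL in this assay, with a range from 2.5 ng.h/mL to 40 ng.h/mL. The estimated step is therefore a 1.1-fold higher number from compound 3 to compound 4 (0.04 log units; within the scatter), which is not expected to go beyond the scatter.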

Compound 4, area under the concentration-time curve: 99 ng.h/mL
Estimate against measurement, compound 4: 9.9-fold (1.00 log units) below; measured number outside the range, above it.
By their numbers in this assay, from the lowest: compound 3; then compound 4; then compound 1.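

In this assay, exchanging one saturated ring for a slightly larger one on a saturated chain carbon bound to two aromatic carbons turns out not to be a neutral swap: piperidin-1-yl in place of pyrrolidin-1-yl gives an 11-fold higher number from compound 3 to compound 4 (1.03 log units; beyond the scatter). Attaching a ring at this carbon still lowers the number strongly, with a 69-fold lower number from compound 1 to compound 4 (1.84 log units; beyond the scatter), but this drop is smaller than a 750-fold lower number from compound 1 to compound 3 (2.88 log units; beyond the scatter), so at this position the outcome depends on which ring is attached and not only on a ring being present. Nothing measured here explains why the two rings differ, and the curve area alone does not show what happens to either compound in the animal.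

For the compounds shown here, with only two rings at this carbon, no trend with ring size can be claimed, and it remains open whether the seven-membered azepan-1-yl would give a higher or a lower number than piperidin-1-yl. On these data alone, it is also open how morpholin-4-yl, which adds an oxygen to the six-membered ring, or an open-chain amine such as dimethylamino would compare on the same carbon.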